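Aryl swap on the pyrazole carbon: compound 2 to compound 3

A few compounds are considered here, and "the series" means these few. Any claim that something is new, unique, unknown or untested is made for them only; others in the source may bear on it.

Among the compounds with values here, compound 2 `Cc1nn(-c2nc(-c3ccc(Cl)c(Cl)c3)c(SC(C)C)s2)c(C(=O)O)c1-c1cccc(F)c1` gives 900 nM in a functional assay on BJAB cells (Homo sapiens) for antiproliferative activity, with a stated time of 4 days (on this read-out higher numbers stand for an effect only at larger amounts of compound and lower numbers for an effect already at smaller amounts), the lowest of the two numbers so far; compound 1 `Cc1nn(-c2nc(-c3ccc(Cl)c(Cl)c3)c(SC(C)C)s2)c(C(=O)O)c1-c1cncnc1` gives 22000 nM. Compound 3 `Cc1cc(-c2c(C)nn(-c3nc(-c4ccc(Cl)c(Cl)c4)c(SC(C)C)s3)c2C(=O)O)cc(C)n1` carries the change (2,6-dimethylpyridin-4-yl in place of 3-fluorophenyl on an aromatic carbon). Within the data shown here, the one measured step that bears on it is a 24-fold lower number from compound 1 to compound 2 (1.39 log units; beyond the scatter), where a six-membered ring with two nitrogens was replaced by a carbon-only ring. Compound 3 moves partly back toward a nitrogen-containing ring, so a clearly higher number is expected, though smaller than that step. The estimated step is a 5.6-fold higher number from compound 2 to compound 3 (0.74 log units; beyond the scatter), giving for compound 3 an expected 5000 nM (range 1500 nM to 20000 nM).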

Compound 3, half-maximal effective concentration: 580 nM
Estimate against measurement, compound 3: 8.6-fold (0.94 log units) above; measured number below the stated range.
By their numbers in this assay, from the lowest: compounds 3 and 2 (each within the scatter of the next); then compound 1.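

In this assay, a nitrogen in the ring at this position does not by itself go with a high number: the change reads a 1.6-fold lower number from compound 2 to compound 3 (0.19 log units; within the scatter), so 2,6-dimethylpyridin-4-yl and 3-fluorophenyl cannot be told apart here. Against pyrimidin-5-yl, the same group gives a 38-fold lower number from compound 1 to compound 3 (1.58 log units; beyond the scatter), so the high number of compound 1 belongs to that ring and not to every nitrogen-containing ring. Nothing available explains this difference. On these data alone, what pyridin-4-yl without the two methyl groups, or with an amine in their place, would give remains open.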